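The compounds below may be only part of what the source reports. "The series", "measured", "known", "first", "only" and "open" are said of these compounds alone.

Of the compounds shown here, two have been measured in a functional assay on MDA-MB-231 cells (Homo sapiens) for antiproliferative activity, read by sulforhodamine B assay, with a stated time of 48 h; a higher number here means a weaker inhibitor, a lower number a stronger inhibitor. Compound 1 (`COc1ccc(C(=O)/C=C\Nc2ccc(-c3nc4cc(OC)c(OC)c(OC)c4s3)cc2C)cc1F`) gives 2900 nM, and compound 2 (`COc1cc(OC)c2sc(-c3ccc(N/C=C\C(=O)c4cc(OC)c(OC)c(OC)c4)c(C)c3)nc2c1`) gives 13800 nM. That second number is the higher of the two, which marks compound 2 as the weaker inhibitor, and the gap lies beyond the usual scatter of repeated measurements. The next compound, compound 3 (`COc1cc(OC)c2sc(-c3ccc(N/C=C\C(=O)c4ccc(OC)c(F)c4)c(C)c3)nc2c1`), departs from compound 2 in one place: 3-fluoro-4-methoxyphenyl stands in place of 3,4,5-trimethoxyphenyl on a carbonyl carbon (3-fluoro-4-methoxyphenyl in place of 3,4,5-trimethoxyphenyl on a carbonyl carbon). For the measured compounds named here, no measured pair shows this change on its own, so the data do not give its size directly. Going by the values given here, the only guide is compound 1, which also carries 3-fluoro-4-methoxyphenyl on a carbonyl carbon and gives 2900 nM, and a single compound is thin support. A moderate move towards a lower number in this assay is therefore expected, estimated as a 2.8-fold lower number from compound 2 to compound 3 (0.44 log units; beyond the scatter), and it may not reach far beyond the scatter. For compound 3 the estimated value is 5000 nM, with an expected range from 1800 nM to 14000 nM.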

Compound 3, half-maximal inhibitory concentration: 13300 nM
Compound 3: the middle estimate sits 2.7-fold (0.42 log units) below what was measured; measured number inside the range.
By their numbers in this assay, from the lowest: compound 1; then compounds 3 and 2 (each within the scatter of the next).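

With the core of compound 2 held fixed, putting 3-fluoro-4-methoxyphenyl in place of 3,4,5-trimethoxyphenyl on a carbonyl carbon gives a 1.0-fold lower number from compound 2 to compound 3 (0.02 log units; within the scatter) in this assay, so the two aryl groups are not distinguished at this position, even though 3-fluoro-4-methoxyphenyl loses some of the heavy atoms and hydrogen-bond acceptors of the group it replaces. The step that does stand out lies elsewhere, on the core: hydrogen in place of methoxy on an aromatic carbon gives a 4.6-fold higher number from compound 1 to compound 3 (0.66 log units; beyond the scatter). With 3-fluoro-4-methoxyphenyl present in both compound 1 and compound 3, the lower number of compound 1 therefore tracks that core methoxy rather than the group on the carbonyl carbon, a reading that rests on this single pair.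

Nothing available here explains why the aryl exchange leaves the number within the scatter or why the core methoxy matters. As far as these compounds go, it remains open whether the aryl exchange would also stay within the scatter on the core of compound 1, and whether a pyridine ring or an aminophenyl group on the carbonyl carbon would behave like these two aryl groups.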